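The compounds below may be only part of what the source reports. "The series", "measured", "known", "first", "only" and "open" are said of these compounds alone.

Compound 1 `O=C(NCN1CCC(c2cccc[n+]2[O-])CC1)c1ccccc1` gives 63%.
Compound 2 `Cc1cc(C)cc(NC(=O)CN2CCC(c3cccc[n+]3[O-])CC2)c1` gives 76%.
Compound 3 `Cc1cccc(NC(=O)CN2CCC(c3ccccc3)CC2)c1` gives 37%.

These values come from a functional assay on HEK293 cells for agonist activity at D(4) dopamine receptor (Homo sapiens), read by FLIPR; a higher number here means a larger maximal response, a lower number a smaller maximal response. Compound 2 stands highest of the three numbers. Its nearest neighbour is compound 1, whose value lies lower by a margin beyond the usual scatter; compound 3 lies furthest away, also beyond the scatter. For the measured compounds named here, no pair among the three differs in only one place, so none of these gaps can be tied to a single structural change.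

The compound not yet measured is compound 4 `O=C(CN1CCC(c2cccc[n+]2[O-])CC1)Nc1cccc(Cl)c1Cl`. Compared with compound 2 it carries a different group on the amide nitrogen: 2,3-dichlorophenyl in place of 3,5-dimethylphenyl on an amide-type nitrogen. Going by the values given here, nothing among the measured compounds shows what such a swap does on its own in this assay; the one other group on that nitrogen, in compound 3, comes with a second change elsewhere. A modest drop from the value of compound 2 is expected, possibly no larger than the scatter. The step this means, a number 11 percentage points lower from compound 2 to compound 4 (beyond the scatter), is estimated as small and downward. For compound 4 the estimate in this assay is 65%, with a range from 45% to 85%.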

Compound 4, largest response reached (reported as efficacy), in percent of the reference or control that the assay uses: 66%
Compound 4: the middle estimate sits 1 percentage points below what was measured; the measured number falls inside the stated range.
By their numbers in this assay, from the lowest: compound 3; then compounds 1, 4 and 2 (each within the scatter of the next, the first and the last beyond it).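

For the compounds shown here, replacing 3,5-dimethylphenyl with 2,3-dichlorophenyl on an amide-type nitrogen gives, in this assay, a number 10 percentage points lower from compound 2 to compound 4 (within the scatter), and this is the first pair that differs in only one place. The swap therefore leaves the two maximal responses indistinguishable: at this place, a phenyl ring carrying two methyl groups and one carrying two chlorine atoms cannot be told apart in this read-out, even though the two groups have the same heavy-atom count and differ in which atoms they contain. No measurement at hand speaks to why the two groups read alike.

On these data alone, what remains open is how far this holds for groups of a different kind on the same nitrogen, such as an unsubstituted phenyl, a cyclohexyl or a pyridyl ring, since both groups compared here are substituted phenyl rings. Steps to compound 3 cannot be read, as it differs from the others in more than one place, so the role of the rest of the molecule in setting the response also stays unresolved.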